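Trimming the acyl group on a tetrahydroquinoline amide

The compounds below may be only part of what the source reports. "The series", "measured", "known", "first", "only" and "open" are said of these compounds alone.

Measured compounds:
- compound 1, `O=C(Nc1cc(C(F)(F)F)cc(C(F)(F)F)c1)C1CCc2ccccc2N1C(=O)c1ccc(Cl)cc1`, 2000 nM
- compound 2, `O=C(Nc1ccccc1O)C1CCc2ccccc2N1`, 5260 nM

Of the compounds shown here, two have been tested in a functional assay on MDA-MB-231 cells (Homo sapiens) for cytotoxicity, read by sulforhodamine B assay, with a stated time of 72 h; a lower number here means a stronger inhibitor of growth, a higher number a weaker inhibitor of growth. Compound 1 gives 2000 nM, the lowest of the two numbers; compound 2 gives 5260 nM, a gap that lies beyond the usual scatter. Compound 2 differs from compound 1 in several places at once, so no single change can be tied to that gap.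

Compound 3, `CC(=O)N1c2ccccc2CCC1C(=O)Nc1cc(C(F)(F)F)cc(C(F)(F)F)c1`, keeps the shared core and the bis(trifluoromethyl)phenyl amide of compound 1 and alters only the group on the ring nitrogen: methyl in place of 4-chlorophenyl on a carbonyl carbon. Within the data shown here, no measured pair shows this exact change, so the size of the step is an expectation rather than a reading. Removing a ring of that size in favour of a single carbon is expected to weaken growth inhibition modestly, a step of a 2.3-fold higher number from compound 1 to compound 3 (0.35 log units; beyond the scatter) in this assay. Compound 3 is therefore estimated at 4500 nM, with a range from 1500 nM to 14000 nM.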

Compound 3, concentration for 50% growth inhibition: > 70000 nM
Compound 3: a limit, no number; the forecaster's own chance of this, stated with the estimate: 15%; middle value at least 15-fold (1.19 log units) away from the limit.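

In this assay, compound 3 gives > 70000 nM, which is a limit of the assay and not a number. The change from 4-chlorophenyl to methyl on this carbonyl carbon comes out as an at least 35-fold higher number from compound 1 to compound 3 (1.54 log units; beyond the scatter), so this position on the ring nitrogen is far less tolerant of the change than the earlier pair could reveal, and the group there has a large bearing on growth inhibition in this series. The value of compound 3 lies at the end of the readable range: the limit of > 70000 nM in this assay, at which 1 of the 3 values shown sits.

From the compounds shown here alone, the true size of the step stays unknown, since only one side of it is a number. Going by these compounds, whether the loss follows the chlorine or the whole ring also stays open: a plain phenyl, or a longer chain such as butyl, on the same carbonyl carbon would separate the two.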